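Triazole series: aryl on the ring nitrogen, cytotoxicity

The source may report more compounds than this note shows. Statements on the series, on what has been measured and on what is new or still open speak of the compounds shown alone.

Of the compounds shown here, three sharing one core have been read in a functional assay on PC-12 cells (Rattus norvegicus) for cytotoxicity, read by MTT assay, with stated times of 2 h and 24 h, tested at 5 uM; on this read-out lower numbers stand for a weaker effect and higher numbers for a stronger effect at the one concentration tested. Compound 1 `Oc1cc(C(F)(F)F)ccc1-c1nc(-c2ccccc2O)n(-c2ccc(OC(F)(F)F)cc2)n1` gives 84.9%. Compound 2 `N#Cc1ccc(-n2nc(-c3ccc(C(F)(F)F)cc3O)nc2-c2ccccc2O)cc1` gives 86.8%. Compound 3 `COc1ccccc1-n1nc(-c2ccc(C(F)(F)F)cc2O)nc1-c1ccccc1O` gives 85.6%, the second highest of the three numbers, with compound 1 nearest and compound 2 furthest, both within the scatter. Two measured steps change the group on the aromatic nitrogen and therefore bear on compound 4: a number 0.7 percentage points higher from compound 1 to compound 3 (within the scatter) and a number 1.2 percentage points lower from compound 2 to compound 3 (within the scatter). Neither moved the read-out beyond the scatter. Compound 4 `Oc1cc(C(F)(F)F)ccc1-c1nc(-c2ccccc2O)n(-c2cc(F)cc(F)c2)n1` differs from compound 3 as follows: 3,5-difluorophenyl in place of 2-methoxyphenyl on an aromatic nitrogen. Since this change again sits on the aromatic nitrogen, no step beyond the scatter is expected in this assay. Compound 4 is estimated at 85.5%, with a range of 78% to 92%. The expected step is a number 0.1 percentage points lower from compound 3 to compound 4 (within the scatter).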

Compound 4, a percentage reported as activity, at one concentration (the size of the read-out at that concentration, not a potency): 100%
Compound 4: middle estimate off by 14.5 percentage points, on the low side; the whole stated range lies below it.
By their numbers in this assay, from the lowest: compounds 1, 3 and 2 (each within the scatter of the next); then compound 4.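

In this assay the group on the aromatic nitrogen is no longer silent: the earlier groups stayed within the scatter of one another, but 3,5-difluorophenyl gives a number 14.4 percentage points higher from compound 3 to compound 4 (beyond the scatter) and a number 13.2 percentage points higher from compound 2 to compound 4 (beyond the scatter) and a number 15.1 percentage points higher from compound 1 to compound 4 (beyond the scatter). So this position can move the read-out, and here only the 3,5-difluorophenyl group does so. Nothing measured here accounts for this change.

From the compounds shown here alone, whether the shift follows the fluorine atoms, their number or their placement on the phenyl ring stays open. So does the reading of an unsubstituted phenyl or an aminophenyl on this nitrogen.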